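The source may report more compounds than this note shows. Statements on the series, on what has been measured and on what is new or still open speak of the compounds shown alone.

Compound 1 `C=CC1C(=O)N(c2cc(OC)c(OC)c(OC)c2)C1c1ccc(OC)cc1`: 10 nM
Compound 2 `CCOc1ccc(C2C(C3CC3)C(=O)N2c2cc(OC)c(OC)c(OC)c2)cc1`: 63 nM
Compound 3 `COc1ccc(C2C(O)C(=O)N2c2cc(OC)c(OC)c(OC)c2)cc1`: 12 nM

In a functional assay on HT-29 cells (Homo sapiens) for inhibition, read by sulforhodamine B assay, with a stated time of 72 h (on this read-out lower numbers stand for stronger inhibition and higher numbers for weaker inhibition), compound 2 gives the highest of the three numbers, beyond the scatter from both compound 3 and compound 1. The unmeasured compound 4 `CCOc1ccc(C2C(Oc3ccccc3)C(=O)N2c2cc(OC)c(OC)c(OC)c2)cc1` differs from compound 2 by phenoxy in place of cyclopropyl on a saturated ring carbon. Within the data shown here, only one measured step touches that ring carbon: a 1.2-fold higher number from compound 1 to compound 3 (0.08 log units; within the scatter). Among the measured compounds shown here, that single swap on the same carbon left the number unchanged, so no clear direction can be drawn from it; the gap from compound 2 to compound 3, with no single-point step connecting them, gives no guide either. Compound 4 is therefore expected to sit near compound 2, with a 1.4-fold lower number from compound 2 to compound 4 (0.15 log units; within the scatter), at an estimated 45 nM in this assay, within a range of 12 nM to 160 nM.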

Compound 4, half-maximal inhibitory concentration: 388 nM
Compound 4: the middle estimate sits 8.6-fold (0.94 log units) below what was measured, outside the stated range (above it).
By their numbers in this assay, from the lowest: compounds 1 and 3 (each within the scatter of the next); then compound 2; then compound 4.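

On this saturated ring carbon, phenoxy in place of cyclopropyl gave a 6.2-fold higher number from compound 2 to compound 4 (0.79 log units; beyond the scatter) in this assay, beyond the scatter. Among these compounds, the earlier swap on this carbon, a 1.2-fold higher number from compound 1 to compound 3 (0.08 log units; within the scatter), lay within the scatter, so only this new step shows that the number can respond to the group placed here. No available evidence accounts for the step. The compounds shown leave open whether the oxygen or the aromatic ring of phenoxy goes with the higher number; a benzyl or cyclohexyloxy group on this carbon would separate the two. Going by these compounds, how an amine here would behave also remains open.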